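Methyl in place of hydrogen on compound 1

The source may report more compounds than this note shows. Statements on the series, on what has been measured and on what is new or still open speak of the compounds shown alone.

Measured values in a physicochemical assay for solubility, read by HPLC (a lower number here means a less soluble compound, a higher number a more soluble compound), are as follows:
compound 1 (`Nc1n[nH]c2cc(-c3ccccc3)[nH]c(=O)c12`) gives 24 ug/mL here
compound 2 (`Nc1n[nH]c2cc(C3CCNCC3)[nH]c(=O)c12`) gives 2340 ug/mL here
compound 3 (`Cc1cc2[nH]nc(N)c2c(N2CCCCC2)n1`) gives 794 ug/mL here

Compound 1 stands lowest of the three, with compound 3 nearest and compound 2 furthest, both beyond the scatter. Compound 4 (`Cn1nc(N)c2c(=O)[nH]c(-c3ccccc3)cc21`) carries methyl in place of hydrogen on an aromatic nitrogen of compound 1 (methyl in place of hydrogen on an aromatic nitrogen). For the measured compounds named here, no measured pair shows this change, so any forecast in this assay is uncertain. A small rise, close to the scatter, is expected. The estimated step of a 1.7-fold higher number from compound 1 to compound 4 (0.22 log units; within the scatter) is correspondingly modest. Compound 4 is estimated at 40 ug/mL in this assay, with 14 ug/mL to 115 ug/mL as the expected range.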

Compound 4, solubility: 76 ug/mL
The estimate for compound 4 lay 1.9-fold (0.28 log units) below the measured number; low and high end bracket the measured number.
By their numbers in this assay, from the lowest: compound 1; then compound 4; then compound 3; then compound 2.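

In this assay methyl in place of hydrogen on an aromatic nitrogen gives a 3.2-fold higher number from compound 1 to compound 4 (0.50 log units; beyond the scatter) and lies beyond the scatter. This is the first change in one place among these compounds, and it shows that adding one carbon at this ring nitrogen is enough to move the read-out. Nothing at hand explains the size or direction of this step.

As far as these compounds go, whether a longer chain or a chain ending in an amine on the same nitrogen would go further stays open. So does whether methyl here gives a similar step on the core of compound 2.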